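The compounds below may be only part of what the source reports. "The series", "measured", "known", "first", "only" and "open" are said of these compounds alone.

Working notes on the series.

Compound 1 `Cc1ccc(CN2CCC(NC(=O)N(CC(=O)C(C)(C)O)Cc3ccc(-c4ccc(F)cc4)cc3)CC2)cc1` gives 4530 nM in an in vitro functional assay on HEK293 cells for antagonist activity at melanin-concentrating hormone receptor 1 (Homo sapiens), read by GTPgammaS binding, with a stated time of 45 min; on this read-out lower numbers stand for stronger inhibition and higher numbers for weaker inhibition. Compound 2 `COc1ccc(-c2ccc(CN(CC(=O)C(C)(C)O)C(=O)NC3CCN(Cc4ccc(C)cc4)CC3)cc2)cc1` carries the change methoxy in place of fluoro on an aromatic carbon relative to compound 1. In this assay compound 2 reaches only a limit of the assay, > 10000 nM. The step of an at least 2.2-fold higher number from compound 1 to compound 2 (0.34 log units; beyond the scatter) is therefore open-ended on the weak side, because the limit of > 10000 nM in this assay, at which 1 of the 3 values shown sits, caps what can be read there. Within the data shown here, compound 3 `CC(=O)OCC(C)(C)NC(=O)N(CCC1CCN(Cc2ccc(C)cc2)CC1)Cc1ccc(-c2ccc(F)cc2)cc1` gives 409 nM in this assay and stands lowest of the two numbers so far; the difference between the core of compound 3 and the core of compound 1 is not broken down here. Compound 4 `COc1ccc(-c2ccc(CN(CCC3CCN(Cc4ccc(C)cc4)CC3)C(=O)NC(C)(C)COC(C)=O)cc2)cc1` has not yet been measured in this assay. Among the measured compounds shown here, it differs from compound 3 by methoxy in place of fluoro on an aromatic carbon, the same change as the one made from compound 1 to compound 2, at the same place. For the measured compounds named here, on that pairing the step from compound 3 to compound 4 in this assay is expected to be a weakening of about a 3.4-fold higher number from compound 3 to compound 4 (0.53 log units; beyond the scatter), set beside an at least 2.2-fold higher number from compound 1 to compound 2 (0.34 log units; beyond the scatter), resting on the single measured pair compound 1 and compound 2. Compound 4 is accordingly estimated at 1400 nM, within 500 nM to 5000 nM.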

Compound 4, antagonist equilibrium constant: 647 nM
Estimate against measurement, compound 4: 2.2-fold (0.34 log units) above; low and high end bracket the measured number.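

The change from 4-fluorophenyl to 4-methoxyphenyl gives a 1.6-fold higher number from compound 3 to compound 4 (0.20 log units; within the scatter) in this assay, so on this core the step cannot be told apart from repeat measurement. Set beside the same change on the other core, the two steps read as follows: the same change on two cores in this assay, an at least 2.2-fold higher number (0.34 log units; beyond the scatter) from compound 1 to compound 2 and a 1.6-fold higher number (0.20 log units; within the scatter) from compound 3 to compound 4; the limit leaves it open whether they differ. Among these compounds, compound 2 stands at a limit and not at a number, so the series does not show whether the size of the step carries from one core to the other, and only a single pair with a number is available: the limit of > 10000 nM in this assay, at which 1 of the 4 values shown sits.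

The compounds shown hold only fluoro and methoxy at this place, on two cores, and leave open how a chloro, a nitrile, an amine or a carboxylic acid would read there in this assay. Also open, on these data alone, is whether the change from 4-fluorophenyl to 4-methoxyphenyl would give a readable step on a third core, or on a core with a longer chain.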